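Halogen swap on the anilino ring of compound 2

The source may hold more compounds than are shown below. What is called first, only, known or untested is meant among the compounds shown, and "the series" means these compounds.

Measured so far:
compound 1 `CCCCCOC1=C(C(=O)c2ccccc2)C(c2ccc(Br)cc2)N(CCCn2ccnc2)C1=O` — 7290 nM
compound 2 `O=C(C1=C(Nc2ccc(I)cc2)C(=O)N(CCCn2ccnc2)C1c1ccc(Br)cc1)c1ccccc1` — 24500 nM

In a functional assay on A549 cells (Homo sapiens) for antiproliferative activity, read by MTT assay, with a stated time of 72 h (a lower number here means a stronger inhibitor, a higher number a weaker inhibitor), compound 2 gives 24500 nM, the highest of the two numbers; its nearest neighbour is compound 1, which in this assay gives 7290 nM. Among the compounds with values here, the one step measured so far, a 3.4-fold higher number from compound 1 to compound 2 (0.53 log units; beyond the scatter), concerns the replacement of pentyloxy by (4-iodophenyl)amino on the double-bonded ring carbon, not the halogen on that anilino ring.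

Compound 3 `O=C(C1=C(Nc2ccc(Cl)cc2)C(=O)N(CCCn2ccnc2)C1c1ccc(Br)cc1)c1ccccc1` differs from compound 2 by chloro in place of iodo on an aromatic carbon. Within the data shown here, no measured pair covers a change of halogen on an aromatic carbon, so nothing shows how large such a step is in this assay. Without a bearing step, the expectation for compound 3 is a number close to that of compound 2, with the step of a 1.2-fold lower number from compound 2 to compound 3 (0.09 log units; within the scatter) expected to stay within the scatter. Compound 3 is therefore estimated at 20000 nM, with a range of 8000 nM to 50000 nM.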

Compound 3, half-maximal inhibitory concentration: 30000 nM
Compound 3: middle estimate off by 1.5-fold (0.18 log units), on the low side; low and high end bracket the measured number.
By their numbers in this assay, from the lowest: compound 1; then compounds 2 and 3 (each within the scatter of the next).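

In this assay, chloro in place of iodo on an aromatic carbon, para to a large group, gives a 1.2-fold higher number from compound 2 to compound 3 (0.09 log units; within the scatter), so the series does not separate these two halogens at this place. The change from pentyloxy now reads with a second anilino substituent: (4-chlorophenyl)amino in place of pentyloxy gives a 4.1-fold higher number from compound 1 to compound 3 (0.61 log units; beyond the scatter), so compound 1 keeps the lowest number with either halogen on the anilino ring. No measured evidence bears on why either step has the size it has.

The compounds shown leave open whether fluoro, methoxy or a plain hydrogen at this place would read the same as chloro and iodo. They also leave open whether an alkoxy chain shorter or longer than pentyloxy would move the number further from that of compound 1.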